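This account rests on a few compounds, and the source may have more. Where it says the series, first, only, none or still open, it means among the compounds named here.

The numbers come from a functional assay on MDA-MB-231 cells (Homo sapiens) for antiproliferative activity, read by MTT assay; on this read-out higher numbers stand for weaker inhibition and lower numbers for stronger inhibition:

Compound 1 `CNC(=O)c1ccc(Oc2cccc(NC(=S)Nc3ccc(F)cc3)c2)nc1` gives 21700 nM.
Compound 2 `CNC(=O)c1ccc(Oc2cccc(NC(=S)Nc3ccc(F)c(C(F)(F)F)c3)c2)nc1` gives 13300 nM.

Compound 1 stands at the higher of the two numbers; its nearest neighbour is compound 2, and the move a 1.6-fold lower number from compound 1 to compound 2 (0.21 log units; within the scatter) stays within the scatter, so the two compounds cannot be ordered on these data. Compound 3 `CNC(=O)c1ccc(Oc2cccc(NC(=S)Nc3ccc(C)c(C)c3)c2)nc1` has not yet been tested in this assay. It differs from compound 1 in one place: 3,4-dimethylphenyl in place of 4-fluorophenyl on an amide-type nitrogen. Within the data shown here, the only measured step, a 1.6-fold lower number from compound 1 to compound 2 (0.21 log units; within the scatter), concerns a trifluoromethyl in place of hydrogen on an aromatic carbon and leaves the 4-fluorophenyl itself in place, so no measured step bears directly on an exchange of the whole group. What the data do show is that a change to this part of the molecule left the number within the scatter. For compound 3 the expected step is a 1.1-fold lower number from compound 1 to compound 3 (0.04 log units; within the scatter), not beyond the scatter in either direction. The estimate for compound 3 in this assay is 20000 nM, within a range from 7000 nM to 55000 nM.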

Compound 3, half-maximal inhibitory concentration: 38600 nM
Beside the measured number, compound 3's estimate is 1.9-fold (0.29 log units) below it; low and high end bracket the measured number.
By their numbers in this assay, from the lowest: compounds 2, 1 and 3 (each within the scatter of the next, the first and the last beyond it).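

With a 1.8-fold higher number from compound 1 to compound 3 (0.25 log units; within the scatter) in this assay as the result, an exchange of the whole group on the amide-type nitrogen can now be read, whereas the earlier step kept the 4-fluorophenyl in place and only added a trifluoromethyl to it. The 3,4-dimethylphenyl holds no fluorine, so compound 3 shows that the fluorine of compound 1 can be lost and two methyl groups brought in without the step from compound 1 leaving the scatter, and these two compounds cannot be ordered on these data. Nothing available explains why the number for compound 3 falls where it does.

On these data alone, the groups compared at this position are all six-membered aromatic carbon rings with no hydrogen-bond donors or acceptors, so it remains open whether an amine or a carboxylic acid on the ring, or a saturated cyclohexyl in its place, would take the number beyond the scatter. As far as these compounds go, it also remains open whether a carbonyl in place of the thiocarbonyl would alter how this position responds to such exchanges.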